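Carbamoyl for hydroxy on the saturated side chain

A few compounds are considered here, and "the series" means these few. Any claim that something is new, unique, unknown or untested is made for them only; others in the source may bear on it.

Going by the values given here, compound 2 `O=S1(=O)Cc2nc(-c3cc(F)c(Cl)cc3F)nc(N3CCC(CO)CC3)c2C1` is the one member of the series with a measured number: in a physicochemical assay for solubility, with a stated time of 20 h, at pH 6.8 (on this read-out lower numbers stand for lower solubility and higher numbers for higher solubility), compound 2 gives 16000 nM. Compound 1 `CN(C)C(=O)C1CCN(c2nc(-c3cc(F)c(Cl)cc3F)nc3c2CS(=O)(=O)C3)CC1` reaches only a limit; in this assay compound 1 gives > 100000 nM, which is a limit of the method (the limit of > 100000 nM in this assay, at which 1 of the 2 values shown sits). Among the compounds with values here, the single measured step, an at least 6.2-fold lower number from compound 1 to compound 2 (0.79 log units; beyond the scatter), is therefore itself known only as a bound. Compound 3 `NC(=O)CC1CCN(c2nc(-c3cc(F)c(Cl)cc3F)nc3c2CS(=O)(=O)C3)CC1` carries carbamoyl in place of hydroxy on a saturated chain carbon bound to a saturated ring carbon. The measured step and this change both concern an amide on the side chain, but the measured pair differs in how the amide is substituted, so its size is only a rough guide. The step from the measured compound is expected to run upward, about a 1.9-fold higher number from compound 2 to compound 3 (0.27 log units; within the scatter), though a move within the scatter cannot be excluded. For compound 3 the estimate in this assay is 30000 nM, with a range from 8000 nM to 120000 nM.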

Compound 3, solubility: 15000 nM
Compound 3: middle estimate off by 2.0-fold (0.30 log units), on the high side; low and high end bracket the measured number.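

In this assay, carbamoyl in place of hydroxy on a saturated chain carbon bound to a saturated ring carbon gives a 1.1-fold lower number from compound 2 to compound 3 (0.03 log units; within the scatter), so this change does not separate the two side chains on this read-out. Carbamoylmethyl in place of dimethylcarbamoyl on a saturated ring carbon gives an at least 6.6-fold lower number from compound 1 to compound 3 (0.82 log units; beyond the scatter), which shows that carrying an amide on the side chain does not by itself bring a compound to the level of compound 1. Compound 1 remains a limit and not a number: the limit of > 100000 nM in this assay, at which 1 of the 3 values shown sits.

Open, from the compounds shown here alone, is whether the gap to compound 1 follows the two methyl groups on the amide nitrogen or the placing of the carbonyl on the chain, which a dimethylcarbamoylmethyl group would separate. Also open, going by these compounds, is how a carboxylic acid or an amine on this chain would read.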